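Adding methoxy to the side chain of compound 2

A few compounds are considered here, and "the series" means these few. Any claim that something is new, unique, unknown or untested is made for them only; others in the source may bear on it.

Measured so far in a physicochemical assay for lipophilicity; on this read-out lower numbers stand for lower lipophilicity and higher numbers for higher lipophilicity:
- compound 1 `CC(C)n1ccc(NC(=O)c2cc(Oc3ccc(C(=O)N4CCC4)cc3)cc(O[C@@H](C)CO)c2)n1`: 2.8
- compound 2 `CC(C)Oc1cc(Oc2ccc(C(=O)N3CCC3)cc2)cc(C(=O)Nc2ccn(C)n2)c1`: 3.3

Of these two, compound 2 stands highest at 3.3 on this scale, and compound 1 reads 2.8. The gap between them lies beyond the scatter. Compound 3 `COC[C@H](C)Oc1cc(Oc2ccc(C(=O)N3CCC3)cc2)cc(C(=O)Nc2ccn(C)n2)c1` changes compound 2 in one place: methoxy in place of hydrogen on a saturated chain carbon, two bonds along the chain from an oxygen on an aromatic ring on a saturated chain carbon, two bonds along the chain from an oxygen on an aromatic ring, so isopropoxy becomes 1-(methoxymethyl)ethoxy. Among the compounds with values here, no measured pair shows this change alone, so the expectation is a judgement. In this assay a fall beyond the scatter is expected, an estimated a number 0.50 log units lower from compound 2 to compound 3 (beyond the scatter) in all. Compound 3 is expected at 2.8, within a range of 2.4 to 3.1.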

Compound 3, distribution coefficient: 2.5
Beside the measured number, compound 3's estimate is 0.30 log units above it, and the stated range covers the measured number.
By their numbers in this assay, from the lowest: compounds 3 and 1 (each within the scatter of the next); then compound 2.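

In this assay the result is a number 0.80 log units lower from compound 2 to compound 3 (beyond the scatter) when methoxy replaces hydrogen on a saturated chain carbon, two bonds along the chain from an oxygen on an aromatic ring. This is the first single change shown at this position, and it proves that the number responds there: isopropoxy becomes the larger 1-(methoxymethyl)ethoxy, yet the number falls. No supporting data explain the size of this fall. From the compounds shown here alone, whether an amine or a carboxylic acid on the same carbon would move the number as far remains open. So does whether methoxy would have the same effect on another core.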